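A few compounds are considered here, and "the series" means these few. Any claim that something is new, unique, unknown or untested is made for them only; others in the source may bear on it.

Measured compounds:
compound 1 `CCOC(=O)c1oc2ccc(NS(=O)(=O)c3cccc(Cl)c3)cc2c1C`, 83900 nM
compound 2 `CCOC(=O)c1oc2ccc(NS(=O)(=O)c3cccc(C(F)(F)F)c3)cc2c1C`, 51400 nM
compound 3 `CCOC(=O)c1oc2ccc(NS(=O)(=O)c3cc(OC)ccc3OC)cc2c1C`, 52300 nM

These three compounds were tested in a functional assay on MCF7 cells (Homo sapiens) for antiproliferative activity, read by MTT assay, with a stated time of 72 h; on this read-out lower numbers stand for stronger inhibition and higher numbers for weaker inhibition. Compound 1 gives 83900 nM, the largest of the three numbers, but its gap to compound 3 at 52300 nM and to compound 2 at 51400 nM is in each case within the scatter, so the three stand together. Going by the values given here, the one single-point step among them, a 1.6-fold lower number from compound 1 to compound 2 (0.21 log units; within the scatter), shows that swapping one substituent on the aryl ring of the sulfonamide left the read-out essentially unchanged; compound 3, with two methoxy groups in place of the chloro, also sits within the scatter of compound 1.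

Compound 4 `CCOC(=O)c1oc2ccc(NS(=O)(=O)c3cccs3)cc2c1C` has not been measured. It differs from compound 1 by thiophen-2-yl in place of 3-chlorophenyl on a sulfonyl sulfur. Among the compounds with values here, no measured step replaces the whole aryl ring, so the only bearing evidence is the within-scatter step from compound 1 to compound 2 and the similar position of compound 3. On that basis compound 4 is expected to show no step beyond the scatter in this assay, that is a 1.2-fold lower number from compound 1 to compound 4 (0.08 log units; within the scatter). Compound 4 is therefore estimated at 70000 nM, within a range of 30000 nM to 160000 nM.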

Compound 4, half-maximal inhibitory concentration: 92300 nM
Estimate against measurement, compound 4: 1.3-fold (0.12 log units) below; low and high end bracket the measured number.
By their numbers in this assay, from the lowest: compounds 2, 3, 1 and 4 (each within the scatter of the next).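

In this assay, exchanging the whole aromatic group on the sulfonyl sulfur, thiophen-2-yl in place of 3-chlorophenyl, gives a 1.1-fold higher number from compound 1 to compound 4 (0.04 log units; within the scatter). The earlier compounds shown here varied only the substituents on a six-membered aromatic ring of carbon only, whereas this change replaces that ring with a five-membered aromatic ring with 1 hetero atom and removes the chlorine, and the read-out still does not move beyond the scatter. This position on the sulfonyl sulfur, whose other neighbour is the sulfonamide nitrogen, therefore accepts a change of ring as well as a change of substituent without a measurable step in this read-out, although no measurement on hand bears on what lies behind that result.

The compounds shown leave open whether any group on the sulfonyl sulfur can move the number beyond the scatter, for instance a non-aromatic group such as a longer alkyl chain or a ring carrying an amine. They also leave open how the read-out would respond to a change elsewhere in the shared core, such as a carboxylic acid in place of the ethyl ester.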